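Swapping the Methoxyphenyl Arm for a Cyclopentylmethyl Chain

A few compounds are considered here, and "the series" means these few. Any claim that something is new, unique, unknown or untested is made for them only; others in the source may bear on it.

Measured compounds:
compound 1 `CCCc1n[nH]c2c(=O)n(NC(=O)c3ccncc3)c(-c3cccc(OC)c3)nc12` gives 0.07%
compound 2 `COc1cccc(Cc2nc3c(-c4ccc(Cl)cc4)n[nH]c3c(=O)n2NC(=O)c2ccccc2)c1` gives 89.3%

Of the compounds shown here, two have been measured in a functional assay on HT-29 cells (Homo sapiens) for cytotoxicity, read by sulforhodamine B assay, with a stated time of 2 days, tested at 100 uM; on this read-out lower numbers stand for less inhibition and higher numbers for more inhibition at the one concentration tested (going by the name of the read-out). Compound 1 `CCCc1n[nH]c2c(=O)n(NC(=O)c3ccncc3)c(-c3cccc(OC)c3)nc12` gives 0.07% in this assay, while compound 2 `COc1cccc(Cc2nc3c(-c4ccc(Cl)cc4)n[nH]c3c(=O)n2NC(=O)c2ccccc2)c1` gives 89.3%, the higher of the two numbers, and the gap to compound 1 lies beyond the scatter. Going by the values given here, the two compounds differ in several places at once, so no single step between them can be read.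

Compound 3 `O=C(Nn1c(CCC2CCCC2)nc2c(-c3ccc(Cl)cc3)n[nH]c2c1=O)c1ccccc1` carries cyclopentylmethyl in place of 3-methoxyphenyl on a saturated chain carbon bound to an aromatic carbon relative to compound 2. Among the compounds with values here, no measured pair shows what such a change does in this assay, so the expectation rests on compound 2 alone, whose value 89.3% leaves room only for a fall. A step downward of moderate size is expected, beyond the scatter, a number 29.3 percentage points lower from compound 2 to compound 3 (beyond the scatter). Compound 3 is estimated to give 60% in this assay, within a range of 20% to 92%.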

Compound 3, a percentage reported as inhibition, at one concentration (the size of the read-out at that concentration, not a potency): 87.3%
For compound 3 the middle estimate is 27.3 percentage points below the measured one, within the range that was stated.
By their numbers in this assay, from the lowest: compound 1; then compounds 3 and 2 (each within the scatter of the next).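

In this assay, going by these compounds alone, the exchange of 3-methoxyphenyl for cyclopentylmethyl on a saturated chain carbon bound to an aromatic carbon gives a number 2 percentage points lower from compound 2 to compound 3 (within the scatter) and is the first single change that can be read. In this pair, the read-out at the one concentration tested therefore does not depend on the six-membered aromatic ring or the hydrogen-bond acceptor of the leaving group, and a five-membered non-aromatic carbon ring serves in their place. No measurement on hand gives a reason for this result.

Going by these compounds, whether an amine, a carboxylic acid or a plain methyl group at this place would keep the read-out in the same range remains open. Compound 1 differs from compound 2 and compound 3 in several places, so the steps to it cannot be read.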